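A few compounds are considered here, and "the series" means these few. Any claim that something is new, unique, unknown or untested is made for them only; others in the source may bear on it.

Measured in a functional assay on HUVEC cells (Homo sapiens) for antiproliferative activity, read by MTT assay, with a stated time of 24 h; on this read-out lower numbers stand for stronger inhibition and higher numbers for weaker inhibition:
Compound 1 `COc1cc(OC)c(-c2coc3cc(OCC(=O)c4cccc(C(F)(F)F)c4)ccc3c2=O)cc1OC`: > 10000 nM (a limit)
Compound 2 `COc1cc(OC)c(-c2coc3cc(OCc4ccc(Br)cc4)ccc3c2=O)cc1OC`: > 10000 nM (a limit)
Compound 3 `COc1cc(OC)c(-c2coc3cc(OCc4ccc(Cl)cc4)ccc3c2=O)cc1OC`: 4400 nM

In this assay, for the measured compounds named here, compound 3 holds the only actual number, 4400 nM. Against it stands (the limit of > 10000 nM in this assay, at which 2 of the 3 values shown sit).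

Compound 4 `COc1cc(OC)c(-c2coc3cc(OCc4ccccc4Cl)ccc3c2=O)cc1OC` carries 2-chlorophenyl in place of 4-chlorophenyl on a saturated chain carbon bound to an oxygen on an aromatic ring. The nearest measured change is an at least 2.2-fold lower number from compound 2 to compound 3 (0.35 log units; beyond the scatter), and the broader one is an at least 2.2-fold lower number from compound 1 to compound 3 (0.35 log units; beyond the scatter). Both show that this side group matters, yet neither moves the chlorine, so neither gives a direction. No step beyond the scatter is therefore expected, and the expected step is a 1.1-fold higher number from compound 3 to compound 4 (0.06 log units; within the scatter). For compound 4 the estimated value is 5000 nM, with an expected range from 2000 nM to 10000 nM.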

Compound 4, half-maximal inhibitory concentration: > 10000 nM
Compound 4: a limit, no number; the forecaster's own chance of this, stated with the estimate: 30%; middle value at least 2.0-fold (0.30 log units) from the limit.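

The change from 4-chlorobenzyl to 2-chlorobenzyl, with the same atoms joined differently, gives an at least 2.2-fold higher number from compound 3 to compound 4 (0.35 log units; beyond the scatter) in this assay. The earlier steps shown here replaced the whole side group or the halogen, whereas this one shows that the place of the chlorine alone matters. For the compounds shown here, compound 3 remains the only compound with an actual number, and compound 4 joins those held at a limit: the limit of > 10000 nM in this assay, at which 3 of the 4 values shown sit.

The steps from compound 1 and compound 2 to compound 4 cannot be read. On these data alone, it remains open how 4-fluorophenyl or 4-methoxyphenyl at this place compares with 4-chlorophenyl.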